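Piperazine Replaces Hydroxymethylpiperidine on the Shared Core

The source may report more compounds than this note shows. Statements on the series, on what has been measured and on what is new or still open speak of the compounds shown alone.

Of the compounds shown here, two have been measured in an ADME assay on microsomes from liver (Rattus norvegicus) for pharmacokinetics; on this read-out lower numbers stand for slow clearance and higher numbers for fast clearance. Compound 1, with structure `OC1CCCN(c2nc(-c3cc(-c4ccon4)n(Cc4ccccc4F)n3)ncc2F)C1`, gives 360 uL/min. Compound 2, with structure `OCC1CCCCN1c1nc(-c2cc(-c3ccon3)n(Cc3ccccc3F)n2)ncc1F`, gives 460 uL/min, the higher of the two numbers, though the step of a 1.3-fold higher number from compound 1 to compound 2 (0.11 log units; within the scatter) lies within the scatter, so the two compounds cannot be ordered on this read-out.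

Compound 3, with structure `Fc1ccccc1Cn1nc(-c2ncc(F)c(N3CCNCC3)n2)cc1-c1ccon1`, has not yet been measured in this assay. It differs from compound 2 at one place: piperazin-1-yl in place of 2-(hydroxymethyl)piperidin-1-yl on an aromatic carbon. Going by the values given here, the only measured step, a 1.3-fold higher number from compound 1 to compound 2 (0.11 log units; within the scatter), swapped one hydroxylated ring for another and produced no change beyond the scatter. Among the compounds with values here, that step bears only loosely on the present one, in which a 2-(hydroxymethyl)piperidin-1-yl group is exchanged for a piperazin-1-yl group, so there is no measured precedent for a large move in either direction.

Compound 3 is therefore expected to give about 380 uL/min in this assay, within a range from 160 uL/min to 900 uL/min. The expected step of a 1.2-fold lower number from compound 2 to compound 3 (0.08 log units; within the scatter) is estimated to stay within the scatter, resting on the small size of a 1.3-fold higher number from compound 1 to compound 2 (0.11 log units; within the scatter).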

Compound 3, intrinsic clearance in a liver preparation (reported as CLH), per the amount of preparation that the assay uses: 72 uL/min
The estimate for compound 3 lay 5.3-fold (0.72 log units) above the measured number, and the stated range ends above it.
By their numbers in this assay, from the lowest: compound 3; then compounds 1 and 2 (each within the scatter of the next).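

In this assay the position on the aromatic carbon ortho to a fluoro group turns out to be sensitive to the choice of ring, which the earlier pair could not show, since its exchange of one hydroxylated ring for another gave only a 1.3-fold higher number from compound 1 to compound 2 (0.11 log units; within the scatter) and stayed within the scatter. Piperazin-1-yl in this position brings a 6.4-fold lower number from compound 2 to compound 3 (0.81 log units; beyond the scatter) and also a 5.0-fold lower number from compound 1 to compound 3 (0.70 log units; beyond the scatter) so that compound 3 stands apart from both hydroxylated compounds, whose numbers cannot be ordered against each other. The change from 2-(hydroxymethyl)piperidin-1-yl leaves the counted hydrogen-bond donors and acceptors as they were and alters the heavy atoms and the ring hetero atoms, yet no measurement here gives a reason for the lower number.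

The compounds shown do not separate the second ring nitrogen of piperazin-1-yl from the loss of the hydroxyl group, and a plain piperidin-1-yl or a morpholin-4-yl in the same position would be needed to tell these apart. From the compounds shown here alone, it also remains open whether a 4-methylpiperazin-1-yl would keep the number of compound 3 or move it back towards those of compounds 1 and 2.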